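The source may report more compounds than this note shows. Statements on the series, on what has been measured and on what is new or still open speak of the compounds shown alone.

Measured compounds:
Compound 1, `O=C(O)CC/C=C\CC1COC(c2ccccc2Cl)OC1c1cccnc1`, gives 48 nM in an assay for inhibition of Thromboxane-A synthase (Homo sapiens), using microsomes; on this read-out lower numbers stand for stronger inhibition and higher numbers for weaker inhibition.
Compound 2, `O=C(O)CC/C=C\CC1COC(c2ccco2)OC1c1cccnc1`, gives 164 nM in this assay.
Compound 3, `CC(C)(Oc1ccc(F)cc1)C1OCC(C/C=C\CCC(=O)O)C(c2cccnc2)O1`, gives 51 nM in this assay.

Compound 3 stands second highest of the three numbers. Its nearest neighbour is compound 1, whose number lies within the scatter of that of compound 3, so the two cannot be told apart. Compound 2 lies furthest off, with a higher number that is beyond the scatter.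

The unmeasured compound is compound 4, `CC(C)(Cc1ccc(F)cc1C#N)C1OCC(C/C=C\CCC(=O)O)C(c2cccnc2)O1`. It differs from compound 3 in one place: a group of 10 heavy atoms (8 carbon, 1 nitrogen, 1 fluorine; one six-membered aromatic ring of carbon only) in place of a group of 8 heavy atoms (6 carbon, 1 oxygen, 1 fluorine; one six-membered aromatic ring of carbon only), on a saturated chain carbon bound to two saturated chain carbons and a saturated ring carbon.

Among the measured compounds shown here, only one measured step exists, a 3.4-fold higher number from compound 1 to compound 2 (0.53 log units; beyond the scatter). That step swaps a group on a saturated ring carbon of the shared core, not on the saturated chain carbon where compound 4 differs from compound 3, and neither group involved in it appears in the present change. For the measured compounds named here, no measured step covers the exchange of a 4-fluorophenoxy group for the entering group, and no compound in the set carries a nitrile. The expectation for compound 4 must rest on the parent alone and is wide.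

Compound 4 is therefore expected to stay near its parent, at an estimated 60 nM, with a range from 20 nM to 200 nM. The expected step, a 1.2-fold higher number from compound 3 to compound 4 (0.07 log units; within the scatter), is estimated to lie within the scatter.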

Compound 4, half-maximal inhibitory concentration: < 10 nM
Compound 4: no number, only a limit; the forecaster's own chance of this, stated with the estimate: 5%; middle value at least 6.0-fold (0.77 log units) from the limit.
By their numbers in this assay, from the lowest: compounds 1 and 3 (each within the scatter of the next); then compound 2. At a limit, below all of these: compound 4.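

Exchanging the 4-fluorophenoxy group for the larger group bearing a nitrile, on the saturated chain carbon bound to two saturated chain carbons and a saturated ring carbon, gives an at least 5.1-fold lower number from compound 3 to compound 4 (0.70 log units; beyond the scatter) in this assay. Among the compounds shown here, the only earlier step, a 3.4-fold higher number from compound 1 to compound 2 (0.53 log units; beyond the scatter), lay on a saturated ring carbon, so this is the first sign that the group at the chain carbon also moves the read-out, and here the number falls. The value for compound 4 is a limit and not a number, so the step shows a direction and a minimum size but not its full extent: the limit of < 10 nM in this assay, at which 1 of the 4 values shown sits.

The compounds shown leave open whether the step belongs to the nitrile or to the carbon that takes the place of the ether oxygen, as the two enter together in compound 4. A 4-fluorobenzyl group without the nitrile, a 4-fluorophenoxy group carrying a nitrile, or a primary amide in place of the nitrile would separate these parts, and a number for compound 4 itself would still be needed to fix the size of the step.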